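Adding methoxy to the unsubstituted phenyl of compound 3

A few compounds are considered here, and "the series" means these few. Any claim that something is new, unique, unknown or untested is made for them only; others in the source may bear on it.

For the measured compounds named here, in a functional assay on DLD-1 cells (Homo sapiens) for antiproliferative activity, read by CellTiter-Glo, with a stated time of 72 h (a lower number here means a stronger inhibitor, a higher number a weaker inhibitor), compound 3 `CC1CCN(C2CCN(S(=O)(=O)c3ccccc3-c3ccccc3)CC2)CC1` gives 0.96 nM, the lowest of the three numbers measured so far. Compound 2 `CC1CCN(C2CCN(S(=O)(=O)c3ccccc3-c3ccc(C(F)(F)F)cc3)CC2)CC1` gives 122 nM, and compound 1 `Cc1ccc(-c2ccccc2S(=O)(=O)N2CCC(N3CCC(C)CC3)CC2)cc1` gives 366 nM.

Compound 4 `COc1ccc(-c2ccccc2S(=O)(=O)N2CCC(N3CCC(C)CC3)CC2)cc1` has methoxy in place of hydrogen on an aromatic carbon, para to a large group, so that phenyl becomes 4-methoxyphenyl (methoxy in place of hydrogen on an aromatic carbon).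

Going by the values given here, two measured steps bear directly on this change, since each replaces a group at that same place with hydrogen. The first is a 380-fold lower number from compound 1 to compound 3 (2.58 log units; beyond the scatter), which removes methyl. The second is a 130-fold lower number from compound 2 to compound 3 (2.10 log units; beyond the scatter), which removes trifluoromethyl. Both are large, and read in reverse, each shows a much higher number once hydrogen gives way to a group. The step of a 3.0-fold lower number from compound 1 to compound 2 (0.48 log units; beyond the scatter) is modest by comparison, so the two substituted compounds lie much closer to each other than to compound 3.

Among the compounds with values here, with only two such groups measured, the series offers no direct evidence on methoxy. A large step towards a higher number is nevertheless expected, landing near the values of the two substituted compounds. The estimated step is a 160-fold higher number from compound 3 to compound 4 (2.19 log units; beyond the scatter). For compound 4 the expected value is 150 nM, with an estimated range of 25 nM to 700 nM.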

Compound 4, half-maximal inhibitory concentration: 1000 nM
Compound 4: the middle estimate sits 6.7-fold (0.82 log units) below what was measured, outside the stated range (above it).
By their numbers in this assay, from the lowest: compound 3; then compound 2; then compound 1; then compound 4.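

In this assay, methoxy in place of hydrogen gives a 1000-fold higher number from compound 3 to compound 4 (3.02 log units; beyond the scatter), so among the compounds shown, methyl, trifluoromethyl and methoxy on this aromatic carbon all give far higher numbers than hydrogen, and none of compounds 1, 2 or 4 goes against this. The choice of group also matters among the substituted compounds, with an 8.2-fold higher number from compound 2 to compound 4 (0.91 log units; beyond the scatter) and a 2.7-fold higher number from compound 1 to compound 4 (0.44 log units; beyond the scatter), both beyond the scatter, placing methoxy at the highest number of the four and showing that this position does not treat all three groups alike. Nothing available accounts for the size of these steps or for the order of the three groups.

From the compounds shown here alone, it remains open whether a smaller atom such as fluorine, or a hydroxyl, an amine or a carboxylic acid, at this place would stay near compound 3 or join the substituted compounds at much higher numbers. Also open, going by these compounds, is whether methoxy on another carbon of the same ring would carry the same cost, and whether the 4-methoxyphenyl result holds in any other assay.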